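Swapping a Thiazolyl for a Pyrazolyl on the Same Core

This account rests on a few compounds, and the source may have more. Where it says the series, first, only, none or still open, it means among the compounds named here.

Measured compounds:
Compound 1, `O=C(O)c1cc(-n2ccnc2)ccc1O`, in a functional assay on the whole organism for inhibition, with Rattus norvegicus as the target, read by paw edema (on this read-out higher numbers stand for an effect only at larger amounts of compound and lower numbers for an effect already at smaller amounts), gives 75 mg/kg.
Compound 2, `O=C(O)c1cc(-c2nccs2)ccc1O`, in this assay gives > 250 mg/kg, which is a limit of the assay and not a number.

Compound 2 therefore stands at the weaker end of what has been measured, and only as a bound: the limit of > 250 mg/kg in this assay, at which 1 of the 2 values shown sits. The change now considered is 1H-pyrazol-1-yl in place of 1,3-thiazol-2-yl on an aromatic carbon, giving compound 3, `O=C(O)c1cc(-n2cccn2)ccc1O`. Going by the values given here, only one measured step bears on it, an at least 3.3-fold higher number from compound 1 to compound 2 (0.52 log units; beyond the scatter), in which the same 1,3-thiazol-2-yl group entered and the number rose beyond the scatter, at least modestly. The change from compound 2 to compound 3 removes that group again and brings in 1H-pyrazol-1-yl, which resembles the 1H-imidazol-1-yl of compound 1 more closely than it does 1,3-thiazol-2-yl. A step back toward the range of compound 1 is therefore expected, that is a lower number, an at least 2.0-fold lower number from compound 2 to compound 3 (0.31 log units; beyond the scatter), though its size is uncertain since compound 2 is known only as a limit. Compound 3 is estimated at 120 mg/kg, in the range 50 mg/kg to 300 mg/kg.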

Compound 3, dose for half-maximal effect: 200 mg/kg
The estimate for compound 3 lay 1.7-fold (0.22 log units) below the measured number; the measured number falls inside the stated range.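

Within this assay, the place on the aromatic carbon meta to a carboxy group and para to a hydroxy group proves sensitive even to a change between two nitrogen-linked rings: the switch from 1H-imidazol-1-yl to 1H-pyrazol-1-yl gives a 2.7-fold higher number from compound 1 to compound 3 (0.43 log units; beyond the scatter). The higher number seen with 1,3-thiazol-2-yl is thus not unique to that group, as both replacements of 1H-imidazol-1-yl shown here move the number up. The change from 1,3-thiazol-2-yl to 1H-pyrazol-1-yl gives an at least 1.2-fold lower number from compound 2 to compound 3 (0.09 log units; that floor lies within the scatter), and its size stays unsettled because compound 2 is known only as a limit: the limit of > 250 mg/kg in this assay, at which 1 of the 3 values shown sits.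

The compounds shown leave open whether a simple amine or a longer alkyl chain at this place would give a number close to that of compound 1 or a higher one. They also leave open whether the same order among these rings would hold with a methyl ester in place of the carboxy group of the shared core.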